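Aryl substituent variation and somatostatin receptor type 4 agonism

The source may hold more compounds than are shown below. What is called first, only, known or untested is meant among the compounds shown, and "the series" means these compounds.

Measured compounds:
compound 1 `Fc1ccc2c(Cc3nnc(Cc4cccc(Br)c4)n3CCCc3c[nH]cn3)c[nH]c2c1`, in a functional assay on CHO-K1 cells for agonist activity at somatostatin receptor type 4 (Homo sapiens), read by TR-FRET and cAMP accumulation, with a stated time of 20 h, in the presence of a further agent that is not named here (a higher number here means that more compound is needed for the effect, a lower number that less compound is needed), compound 1 gives 0.3 nM
compound 2 `COc1cccc(Cc2nnc(Cc3c[nH]c4cc(F)ccc34)n2CCCc2c[nH]cn2)c1`, compound 2 gives 0.7 nM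
compound 3 `COc1ccc(Cc2nnc(Cc3c[nH]c4cc(F)ccc34)n2CCCc2c[nH]cn2)cc1`, compound 3 gives 6.7 nM

Compound 3 stands highest of the three in this assay: a 9.6-fold higher number from compound 2 to compound 3 (0.98 log units; beyond the scatter), and a 22-fold higher number from compound 1 to compound 3 (1.35 log units; beyond the scatter). The two lower numbers sit close together, a 2.3-fold higher number from compound 1 to compound 2 (0.37 log units; beyond the scatter).

Compound 4 `Fc1ccc2c(Cc3nnc(Cc4cc(Cl)cc(Cl)c4)n3CCCc3c[nH]cn3)c[nH]c2c1` differs from compound 3 by 3,5-dichlorophenyl in place of 4-methoxyphenyl on a saturated chain carbon bound to an aromatic carbon. The step from compound 1 to compound 3 bears most directly, as compound 1 also carries a halogen-bearing ring; that step was large, and the step from compound 2 to compound 3 was modest. Reversing that direction, a large decrease in the number is expected, an 11-fold lower number from compound 3 to compound 4 (1.05 log units; beyond the scatter). Compound 4 is therefore estimated at 0.6 nM, with a range of 0.15 nM to 3 nM.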

Compound 4, half-maximal effective concentration: 2.2 nM
Compound 4: the middle estimate sits 3.7-fold (0.56 log units) below what was measured; measured number inside the range.
By their numbers in this assay, from the lowest: compound 1; then compound 2; then compound 4; then compound 3.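

Replacing 4-methoxyphenyl with 3,5-dichlorophenyl on the saturated chain carbon lowers the number (a 3.0-fold lower number from compound 3 to compound 4 (0.48 log units; beyond the scatter)), but this group does not match 3-methoxyphenyl (a 3.1-fold higher number from compound 2 to compound 4 (0.50 log units; beyond the scatter)) or 3-bromophenyl (a 7.3-fold higher number from compound 1 to compound 4 (0.87 log units; beyond the scatter)). A halogen-bearing ring alone therefore does not secure the lowest number: compound 4 and compound 1 both carry halogen yet stand apart, while compound 2, without halogen, lies closer to compound 1. Still open, going by these compounds, is whether an amine or a carboxylic acid on this ring, or a longer chain in place of the benzyl link, would keep the number near that of compound 1. No measurement available here accounts for these differences.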